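The source may hold more compounds than are shown below. What is called first, only, known or untested is meant among the compounds shown, and "the series" means these compounds.

Measured compounds:
compound 1, `CC1(c2ccccc2)CC(=O)N(CC(=O)N2CCN(c3cccc(Cl)c3)CC2)C1=O`: 300 mg/kg
compound 2, `CC1(c2ccccc2)CC(=O)N(CC(=O)N2CCN(c3ccccc3Cl)CC2)C1=O`: "not active" (no number reported)

The study concerns two close analogues that share one core and differ only in the aryl group on the piperazine nitrogen. In a functional assay on the whole organism (strain CD-1) with Mus musculus as the target, in the maximal electroshock model, with a stated time of 2 h (a lower number here means that less compound is needed, a higher number that more compound is needed for the effect), compound 1 gives 300 mg/kg. In this assay compound 2 is reported as "not active" (no number reported), so no number stands for it, and no step between compound 1 and compound 2 can be counted; all that can be said is that compound 1 reaches an effect at the dose shown and compound 2 does not.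

The next analogue, compound 3, `CC1(c2ccccc2)CC(=O)N(CC(=O)N2CCN(c3ccc(F)cc3)CC2)C1=O`, has not yet been tested. It differs from compound 2 in a single place: 4-fluorophenyl in place of 2-chlorophenyl on an amine nitrogen in a ring. Compound 2 carries no number in this assay. Among the compounds with values here, no direction and no size of step can be stated from it. Within the data shown here, the only anchor is compound 1 with 300 mg/kg, which shows that an aryl group of this kind on the ring nitrogen can give a measurable dose. The author therefore expects compound 3 to land near that anchor, if it is active at all, and estimates for compound 3 a value of 300 mg/kg, within the range 100 mg/kg to 300 mg/kg.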

Compound 3, minimum effective dose: 100 mg/kg
Beside the measured number, compound 3's estimate is 3.0-fold (0.48 log units) above it; low and high end bracket the measured number.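

In this assay, within the data shown here, 4-fluorophenyl in place of 3-chlorophenyl on the ring nitrogen gives a 3.0-fold lower number from compound 1 to compound 3 (0.48 log units; beyond the scatter), so this position can hold an aryl group that needs less compound than the only earlier measured analogue. The steps to and from compound 2 cannot be read, as it has no number, but compound 3 shows that replacing its 2-chlorophenyl group with 4-fluorophenyl gives a compound with a reported dose, so the aryl group here can separate a measurable dose from a report of "not active". No measurement shown bears on why the aryl group changes the result in this way.

The halogen and its place on the ring change together in both comparisons, so the compounds shown do not separate the two, and 4-chlorophenyl and 3-fluorophenyl would be the direct tests. They also leave open how plain phenyl or 4-methoxyphenyl would behave at this nitrogen, and whether the lower dose of compound 3 extends beyond these halogen-bearing rings.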